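Cytotoxicity of Three Analogues and an Untested Fourth

The source may report more compounds than this note shows. Statements on the series, on what has been measured and on what is new or still open speak of the compounds shown alone.

Three compounds share one core and differ only in the group on a carbonyl carbon. Compound 1 `CC(=O)c1ccn(-c2ccc3c(c2)B(O)OC3)c1` carries a methyl there, compound 2 `O=C(c1ccn(-c2ccc3c(c2)B(O)OC3)c1)c1ccccc1Cl` a 2-chlorophenyl, and compound 3 `Cc1ccccc1C(=O)c1ccn(-c2ccc3c(c2)B(O)OC3)c1` a 2-methylphenyl. In an ADME assay on L929 cells (Mus musculus) for cytotoxicity, read by resazurin assay, with a stated time of 72 h (on this read-out higher numbers stand for weaker inhibition and lower numbers for stronger inhibition), compound 1 reaches only the limit > 10 ug/mL. In this assay compound 2 likewise gives only the limit > 10 ug/mL. In this assay compound 3 also stops at the limit > 10 ug/mL, so it stands with the other two at the limit of > 10 ug/mL in this assay, at which 3 of the 3 values shown sit. The steps a step that the two limits leave unreadable from compound 1 to compound 2, a step that the two limits leave unreadable from compound 1 to compound 3 and a step that the two limits leave unreadable from compound 2 to compound 3 therefore cannot be sized. Compound 4 `O=C(c1ccc(CO)cc1)c1ccn(-c2ccc3c(c2)B(O)OC3)c1` differs by 4-(hydroxymethyl)phenyl in place of 2-methylphenyl on a carbonyl carbon. With no readable step to lean on, the step that the limit leaves unreadable from compound 3 to compound 4 is estimated near zero. The value for compound 4 is estimated at 20 ug/mL, ranging from 8 ug/mL to 50 ug/mL.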

Compound 4, half-maximal inhibitory concentration: 9.31 ug/mL
Compound 4: middle estimate off by 2.1-fold (0.33 log units), on the high side, within the range that was stated.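

Among these compounds, at this place on the carbonyl carbon, 4-(hydroxymethyl)phenyl gives the first real number in this assay, while the other groups leave only a limit: the limit of > 10 ug/mL in this assay, at which 3 of the 4 values shown sit. Set against those limits, the change gives an at least 1.0-fold lower number from compound 3 to compound 4 (0.03 log units; that floor lies within the scatter), an at least 1.0-fold lower number from compound 2 to compound 4 (0.03 log units; that floor lies within the scatter) and an at least 1.0-fold lower number from compound 1 to compound 4 (0.03 log units; that floor lies within the scatter). Going by these compounds, each of these is only a floor, so the true size of the change remains unknown, and the steps among the three limits cannot be read.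

Still open, on these data alone, is whether an amine or a carboxylic acid in place of the hydroxyl of the 4-(hydroxymethyl)phenyl group would shift the number in this assay.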